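The source may hold more compounds than are shown below. What is called first, only, known or untested is meant among the compounds shown, and "the series" means these compounds.

Working notes on the series, values from a functional assay on microsomes for inhibition, with a stated time of 1 h; on this read-out higher numbers stand for weaker inhibition and lower numbers for stronger inhibition:

- compound 1 `CCOC(=O)c1cnn(-c2nc(-c3ccc(OC)cc3)c(C#N)c(=O)n2C)c1N`: 68 ug/mL
- compound 2 `CN(C)c1ccc(-c2nc(NN)n(C)c(=O)c2C#N)cc1`: 63 ug/mL
- compound 3 `CSc1nc(-c2ccccc2O)c(C#N)c(=O)n1C`: 44 ug/mL

The three values lie within the usual scatter of one another, so compound 1 cannot be separated from compound 2 or compound 3 on these numbers. All three sit in the same narrow band, and the data give no order among them.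

The next compound is compound 4 `CCOC(=O)c1cnn(-c2nc(-c3ccc(N(C)C)cc3)c(C#N)c(=O)n2C)c1N`, which keeps the core of compound 1 and its substituents except at one place. The change is dimethylamino in place of methoxy on an aromatic carbon, para to a large group, so that 4-methoxyphenyl becomes 4-(dimethylamino)phenyl.

No measured pair in the series differs in one place only, so the size of this change is not shown directly. The nearest hint is that compound 2, which also carries 4-(dimethylamino)phenyl, gives 63 ug/mL, inside the same band. No shift beyond the scatter is therefore expected in this assay, in either direction, and the expected step is a 1.1-fold lower number from compound 1 to compound 4 (0.05 log units; within the scatter). For compound 4 the estimated value is 60 ug/mL, with an expected range of 30 ug/mL to 120 ug/mL.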

Compound 4, half-maximal inhibitory concentration: 111 ug/mL
Beside the measured number, compound 4's estimate is 1.9-fold (0.27 log units) below it; low and high end bracket the measured number.
By their numbers in this assay, from the lowest: compounds 3, 2, 1 and 4 (each within the scatter of the next, the first and the last beyond it).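

Going by these compounds alone, this is the first pair that differs in one place only, so the change now has a directly read size: in this assay, dimethylamino in place of methoxy on an aromatic carbon, para to a large group, gives a 1.6-fold higher number from compound 1 to compound 4 (0.21 log units; within the scatter), with the rest of compound 1 unchanged. At this place on the core of compound 1, the read-out therefore does not separate 4-methoxyphenyl from 4-(dimethylamino)phenyl, and the step gives no ground for ranking one group over the other. Nothing on hand bears on this result beyond the numbers themselves.

The compounds shown leave open whether any group at this place can move the number beyond the scatter, for instance a carboxylic acid, a primary amine or a longer alkoxy chain such as butoxy in place of methoxy. They also leave open whether the same exchange of methoxy for dimethylamino gives a similar step when the other substituents on the core differ from those of compound 1.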